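Adding a methyl to a side chain: what to expect

The compounds below may be only part of what the source reports. "The series", "measured", "known", "first", "only" and "open" are said of these compounds alone.

Of the compounds shown here, three have been tested in a functional assay on HEK293 cells for activation of melanin-concentrating hormone receptor 1 (Homo sapiens), read by inositol phosphate accumulation; on this read-out lower numbers stand for an effect already at smaller amounts and higher numbers for an effect only at larger amounts of compound. Compound 1 `CCCc1cc(N)c2cc(NC(=O)/C=C/c3ccc(C(C)(C)C)cc3)ccc2n1` gives 910 nM, compound 2 `CCCc1cc(N)c2cc(NC(=O)/C=C/c3ccc(C(C)C)cc3)ccc2n1` gives 520 nM, and compound 3 `CC(C)c1cc(N)c2cc(NC(=O)/C=C/c3ccc(C(F)(F)F)cc3)ccc2n1` gives 160 nM. Compound 1 differs from compound 2 by methyl in place of hydrogen on a saturated chain carbon bound to an aromatic carbon and two saturated chain carbons, and that change made a 1.8-fold higher number from compound 2 to compound 1 (0.24 log units; within the scatter). The difference between the cores of compound 2 and compound 3 is not broken down here. Compound 4 `CCC(C)c1cc(N)c2cc(NC(=O)/C=C/c3ccc(C(F)(F)F)cc3)ccc2n1` is not yet measured in this assay; it differs from compound 3 by methyl in place of hydrogen on a saturated chain carbon, two bonds along the chain from an aromatic carbon. This is the same kind of change as before, but not the same: earlier the methyl entered on a saturated chain carbon bound to an aromatic carbon and two saturated chain carbons, here on a saturated chain carbon two bonds along the chain from an aromatic carbon. Since the earlier methyl step a 1.8-fold higher number from compound 2 to compound 1 (0.24 log units; within the scatter) was small, compound 4 is expected to show a similarly small step a 1.5-fold higher number from compound 3 to compound 4 (0.18 log units; within the scatter). Compound 4 is estimated at about 240 nM, most likely between 100 nM and 550 nM.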

Compound 4, half-maximal effective concentration: 44 nM
Beside the measured number, compound 4's estimate is 5.5-fold (0.74 log units) above it; measured number below the stated range.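

In this assay, adding the methyl this time gave a 3.6-fold lower number from compound 3 to compound 4 (0.56 log units; beyond the scatter), a step in the opposite direction to the earlier one. Set side by side, the two methyl steps do not carry over from one core to the other: the same change on two cores in this assay, a 1.8-fold higher number (0.24 log units; within the scatter) from compound 2 to compound 1 and a 3.6-fold lower number (0.56 log units; beyond the scatter) from compound 3 to compound 4, 6.4-fold (0.80 log units) apart, beyond the scatter of two such steps This shows that the effect of adding a methyl in this series cannot simply be read across from one compound pair to another, but it does not show why, as the two methyls enter at different places on different cores and two steps give no rule for a further core.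

The compounds shown leave open whether a longer chain or an amine in place of the new methyl would lower the number further or raise it again.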